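Antiproliferative series: indol-3-yl in place of 2-phenylethenyl

The source may hold more compounds than are shown below. What is called first, only, known or untested is meant among the compounds shown, and "the series" means these compounds.

Within the data shown here, compound 3 `CC(=O)Oc1ccc2cc(-n3cc(/C=C/c4ccccc4)nn3)c(=O)oc2c1C` is the only member of the series with a read number in a functional assay on MCF7 cells (Homo sapiens) for antiproliferative activity; a higher number here means a weaker inhibitor, a lower number a stronger inhibitor: compound 3 gives 28500 nM. Compound 1 `CC(=O)Oc1ccc2cc(-n3cc(-c4ccc(C)cc4)nn3)c(=O)oc2c1C` reaches only a limit of the assay, > 100000 nM. Compound 2 `CC(=O)Oc1ccc2cc(-n3cc(-c4ccc(F)cc4F)nn3)c(=O)oc2c1C` likewise gives only a limit, > 100000 nM. Both sit at the limit of > 100000 nM in this assay, at which 2 of the 3 values shown sit. Compound 4 `CC(=O)Oc1ccc2cc(-n3cc(-c4c[nH]c5ccccc45)nn3)c(=O)oc2c1C` carries 1H-indol-3-yl in place of 2-phenylethenyl on an aromatic carbon. Among the measured compounds shown here, the steps that bear on this are an at least 3.5-fold lower number from compound 1 to compound 3 (0.54 log units; beyond the scatter) and an at least 3.5-fold lower number from compound 2 to compound 3 (0.54 log units; beyond the scatter), each replacing a six-membered aromatic ring of carbon only with 2-phenylethenyl; the step that the two limits leave unreadable from compound 1 to compound 2 is not readable. Compound 4 brings back an aromatic group, here with one hydrogen-bond donor, so a step of a 1.6-fold higher number from compound 3 to compound 4 (0.20 log units; within the scatter) toward weaker inhibition is expected. Compound 4 is estimated at 45000 nM, within 12000 nM to 150000 nM.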

Compound 4, half-maximal inhibitory concentration: 7450 nM
The estimate for compound 4 lay 6.0-fold (0.78 log units) above the measured number, and the stated range ends above it.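

At this position in this assay, 1H-indol-3-yl improves on 2-phenylethenyl, with a 3.8-fold lower number from compound 3 to compound 4 (0.58 log units; beyond the scatter), so a directly attached aromatic group need not leave the series at the assay limit. The steps from the substituted phenyl groups, an at least 13-fold lower number from compound 2 to compound 4 (1.12 log units; beyond the scatter) and an at least 13-fold lower number from compound 1 to compound 4 (1.12 log units; beyond the scatter), are bounds only: the limit of > 100000 nM in this assay, at which 2 of the 4 values shown sit.

Going by these compounds, whether the hydrogen-bond donor or the fused ring carries the step stays open. A 1-methylindol-3-yl or benzofuran-3-yl group would bear on that question.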